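The source may hold more compounds than are shown below. What is called first, only, known or untested is meant among the compounds shown, and "the series" means these compounds.

Measured compounds:
- compound 1, `COc1cccc(Nc2nc(Oc3cccc(NC(=O)/C=C/C(C)C)c3)c3sccc3n2)c1`: 23400 nM
- compound 2, `C=CC(=O)Nc1cccc(Oc2nc(Nc3cccc(C#N)c3)nc3ccsc23)c1`: 3790 nM

In a functional assay on A-431 cells (Homo sapiens) for inhibition, read by MTT assay, with a stated time of 72 h (a higher number here means a weaker inhibitor, a lower number a stronger inhibitor), compound 2 gives the lowest of the two numbers; compound 1 gives the higher one, and the gap between them lies beyond the scatter. Compound 3, `CC(C)/C=C/C(=O)Nc1cccc(Oc2nc(Nc3cccc(C#N)c3)nc3ccsc23)c1`, has not been measured. It differs from compound 2 by 3-methylbut-1-en-1-yl in place of vinyl on a carbonyl carbon. Among the compounds with values here, no step between measured compounds isolates this change, yet compound 1, which carries the same chain, gives 23400 nM. For compound 3 a step to a weaker inhibitor is expected, a 3.2-fold higher number from compound 2 to compound 3 (0.50 log units; beyond the scatter). Compound 3 is estimated at 12000 nM, within 4000 nM to 36000 nM.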

Compound 3, half-maximal inhibitory concentration: 24100 nM
The estimate for compound 3 lay 2.0-fold (0.30 log units) below the measured number; the measured number falls inside the stated range.
By their numbers in this assay, from the lowest: compound 2; then compounds 1 and 3 (each within the scatter of the next).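

Taken alone, the change from vinyl to 3-methylbut-1-en-1-yl on a carbonyl carbon gives a 6.4-fold higher number from compound 2 to compound 3 (0.80 log units; beyond the scatter) in this assay, which the earlier compounds could not isolate. With that chain held fixed, cyano in place of methoxy on an aromatic carbon gives a 1.0-fold higher number from compound 1 to compound 3 (0.01 log units; within the scatter) in this assay, so the two compounds cannot be told apart here. Still open, from the compounds shown here alone, is whether a chain ending in a dimethylamino group would keep the lower number of compound 2, and whether cyano and methoxy would also match on a vinyl compound. No measurement shown offers a reason for either step.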